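The compounds below may be only part of what the source reports. "The series", "measured", "known", "first", "only" and "open" are said of these compounds alone.

Measured so far:
- Compound 1 `Cc1nn2c(-c3nc4cc(Cl)c(F)cc4[nH]3)c(-c3ccc(F)cc3)nc2s1`: > 30000 nM
- Compound 2 `Cc1ccc(-c2nc3sc(C)nn3c2-c2nc3cc(Cl)ccc3[nH]2)cc1`: 7300 nM

The read-out throughout is a functional assay on DU-145 cells (Homo sapiens) for antiproliferative activity, read by MTT assay; a higher number here means a weaker inhibitor, a lower number a stronger inhibitor. Going by the values given here, compound 2, at 7300 nM, holds the only actual number so far. Compound 1 is recorded at > 30000 nM, which is a limit of the assay and not a number.

Compound 3 `Cc1ccc(-c2nc3sc(C)nn3c2-c2nc3cc(Cl)c(F)cc3[nH]2)cc1` is still to be measured in this assay. It carries fluoro in place of hydrogen on an aromatic carbon of compound 2, ortho to a chloro group (fluoro in place of hydrogen on an aromatic carbon). Among the compounds with values here, no measured pair isolates a single change, so the data offer no direct size for this step. The expectation rests on compound 2 at 7300 nM as its starting point, and a single-atom change of this kind is expected to shift the value only modestly, leaning towards weaker inhibition. The expected size of the step is a 1.4-fold higher number from compound 2 to compound 3 (0.14 log units; within the scatter). A reading that returns only a limit remains possible, given (the limit of > 30000 nM in this assay, at which 1 of the 2 values shown sits). For compound 3 the estimated value is 10000 nM, with an expected range of 3500 nM to 30000 nM.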

Compound 3, half-maximal inhibitory concentration: 11800 nM
The estimate for compound 3 lay 1.2-fold (0.07 log units) below the measured number; measured number inside the range.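

In this assay, the step at this position can now be read directly: a 1.6-fold higher number from compound 2 to compound 3 (0.21 log units; within the scatter). Fluoro in place of hydrogen on this aromatic carbon, ortho to a chloro group, therefore leaves compound 3 within the scatter of compound 2, so this one pair shows that the position accepts fluoro without a readable change in the value. Going by these compounds alone, the other step, methyl in place of fluoro on an aromatic carbon, is the first to lie beyond the scatter: an at least 2.5-fold lower number from compound 1 to compound 3 (0.40 log units; beyond the scatter). Compound 1 is recorded at a limit of the assay, so the size of that step is only a bound: the limit of > 30000 nM in this assay, at which 1 of the 3 values shown sits.

Going by these compounds, each change rests on a single pair, so it remains open whether the fluoro result at this position would extend to a larger group such as methoxy or to an amine. On these data alone, it is also open how a longer chain or a carboxylic acid in place of the methyl group would read in this assay.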